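This account rests on a few compounds, and the source may have more. Where it says the series, first, only, none or still open, it means among the compounds named here.

Working notes on the series, read in a functional assay on PC-3 cells (Homo sapiens) for cytotoxicity, read by MTT assay, with a stated time of 72 h; on this read-out lower numbers stand for stronger inhibition and higher numbers for weaker inhibition. Going by the values given here, compound 1 `CC(C)=CCOc1ccc(C(=O)/C=C/c2ccccc2)c(O)c1` gives 71000 nM, the only true number available so far. Compound 2 `C=C(C)CCOc1c(OC)cc(/C=C/CO)cc1OC` reads > 100000 nM, which is a limit of the assay and not a number. The evidence on the scale is therefore thin: the limit of > 100000 nM in this assay, at which 1 of the 2 values shown sits. Among the compounds with values here, compound 1 has no measured neighbour to be ranked against, and no step between two measured compounds exists to calibrate the size of a single change.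

The next compound to consider is compound 3 `CC(C)=CCOc1ccc(C(=O)/C=C/c2ccc(O)cc2)c(O)c1`, which departs from compound 1 by one change, (hydroxy in place of hydrogen on an aromatic carbon). This is hydroxy in place of hydrogen on an aromatic carbon, phenyl to 4-hydroxyphenyl, and the rest of the structure stays the same.

Within the data shown here, with no measured step to draw on, the expectation in this assay is a change no larger than the scatter, in neither direction, so compound 1 at 71000 nM serves as the sole anchor. The expected shift is a 1.4-fold lower number from compound 1 to compound 3 (0.15 log units; within the scatter). For compound 3 the estimated value is 50000 nM, with an expected range of 18000 nM to 100000 nM.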

Compound 3, half-maximal inhibitory concentration: > 100000 nM
Compound 3: a limit, no number (the forecaster's own chance of this, stated with the estimate: 20%); middle value at least 2.0-fold (0.30 log units) away from the limit.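

Compound 3 reads > 100000 nM in this assay, which is a limit of the assay and not a number. The change from phenyl to 4-hydroxyphenyl gives the series its first step, an at least 1.4-fold higher number from compound 1 to compound 3 (0.14 log units; that floor lies within the scatter), so this position now has a direction of reading but no measured size: the added hydroxy does not bring the number lower than that of compound 1, and the floor of the step does not separate a real weakening from scatter. The scale also leaves little room for reading further single changes in this series: the limit of > 100000 nM in this assay, at which 2 of the 3 values shown sit.

Going by these compounds, the true distance between compound 1 and compound 3 stays open, as does whether the para position matters for the hydroxy group or any other substituent would read the same. An amine or a carboxylic acid at this place on the phenyl ring, or a longer chain in place of the ether chain of compound 1, would show whether any change to the core of compound 1 can move the number lower than the value of compound 1 at 71000 nM.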